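Swapping a furan for a substituted benzyl: acid dissociation

A few compounds are considered here, and "the series" means these few. Any claim that something is new, unique, unknown or untested is made for them only; others in the source may bear on it.

Measured so far:
- compound 1, `COc1cccc(CNCCCNc2ccnc3cc(-c4ccc(C(C)(C)C)cc4)ccc23)c1O`: 9.47
- compound 2, `COc1cccc(CNCCCNc2ccnc3cc(Cc4ccc(F)cc4)ccc23)c1O`: 9.47
- compound 3, `c1ccc(-c2ccc3c(NCCCNCc4ccco4)ccnc3c2)cc1`: 9.47

In a physicochemical assay for acid dissociation, compound 1 gives 9.47, compound 2 gives 9.47, and compound 3 gives 9.47. Among the measured compounds shown here, the only single-point step among them, no change at the digits printed from compound 1 to compound 2 (within the scatter), shows that changing the group on the aromatic carbon leaves the value where it was. For the measured compounds named here, compound 3, which differs from compound 1 and from compound 2 in more than one place, sits level with both of them in this assay, so nothing measured so far moves the number.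

Compound 4, `COc1cccc(CNCCCNc2ccnc3cc(-c4ccccc4)ccc23)c1O`, is the step from compound 3 with 2-hydroxy-3-methoxyphenyl in place of furan-2-yl on a saturated chain carbon bound to an amine nitrogen. Going by the values given here, no measured step covers this particular change: the step from compound 1 to compound 2 concerns the other end of the molecule. What can be said is that compound 1 and compound 2 already carry the 2-hydroxy-3-methoxybenzyl group on the amine nitrogen and give the same value as compound 3, which carries the (furan-2-yl)methyl group there. Compound 4 is therefore expected to show no step beyond the scatter, no change at the digits printed from compound 3 to compound 4 (within the scatter), and its estimated value in this assay is 9.47, ranging from 9.1 to 9.8.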

Compound 4, acid dissociation constant: 9.47
Estimate against measurement, compound 4: no gap at the digits printed, within the range that was stated.
By their numbers in this assay, from the lowest: compounds 1, 2, 3 and 4 (each within the scatter of the next).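

In this assay, among the compounds shown here, the direct swap of (furan-2-yl)methyl for 2-hydroxy-3-methoxybenzyl on the amine nitrogen gives no change at the digits printed from compound 3 to compound 4 (within the scatter), so for the first time this change is read on its own, with everything else in the molecule held the same. The entering group has 9 heavy atoms against 5 and 1 hydrogen-bond donor against 0, yet the read-out stays level, and the two changes on an aromatic carbon agree: phenyl in place of 4-fluorobenzyl gives no change at the digits printed from compound 2 to compound 4 (within the scatter) and hydrogen in place of tert-butyl gives no change at the digits printed from compound 1 to compound 4 (within the scatter), which extends the flat picture to a bare phenyl compound. Nothing available explains why the number stays level.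

The compounds shown leave open whether a different kind of group on the amine nitrogen, such as a carboxylic acid or a second amine, would shift the value. They also leave open whether a longer chain carrying that nitrogen would do so, since all four compounds share the same chain.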